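The source may report more compounds than this note shows. Statements on the series, on what has been measured and on what is new or still open speak of the compounds shown alone.

Compound 1 `COc1ccc(C2=C(c3ccc(SC)cc3)CC3CCCN3C2=O)cc1OC(=O)CNC(=O)OC(C)(C)C`: 6000 nM
Compound 2 `COc1ccc(C2=C(c3ccc(SC)cc3)CC3CCCN3C2=O)cc1Br`: 6000 nM
Compound 3 `COc1ccc(C2=C(c3ccc(SC)cc3)CC3CCCN3C2=O)cc1C`: 400 nM

In a functional assay on MCF-A cells (Homo sapiens) for cytotoxicity (a higher number here means a weaker inhibitor of growth, a lower number a stronger inhibitor of growth), compound 3 has the lowest number of the three, 400 nM. Compound 4 `CSc1ccc(C2=C(c3ccc(C)c(C)c3)C(=O)N3CCCC3C2)cc1` has methyl in place of methoxy on an aromatic carbon, turning 4-methoxy-3-methylphenyl into 3,4-dimethylphenyl. Going by the values given here, no measured step touches the methoxy. All three change another group on that ring: no change at the digits printed from compound 1 to compound 2 (within the scatter), a 15-fold lower number from compound 2 to compound 3 (1.18 log units; beyond the scatter) and a 15-fold lower number from compound 1 to compound 3 (1.18 log units; beyond the scatter). These steps show that one swap on this ring can matter a great deal, but they cannot be carried directly over to the new change. Among the compounds with values here, with compound 3 at 400 nM, the lowest value so far, a moderate rise is expected rather than a further drop. The expected step is a 2.3-fold higher number from compound 3 to compound 4 (0.35 log units; beyond the scatter). For compound 4 the estimated value is 900 nM, with an expected range of 250 nM to 3500 nM.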

Compound 4, concentration for 50% growth inhibition: 800 nM
Compound 4: the middle estimate sits 1.1-fold (0.05 log units) above what was measured, within the range that was stated.
By their numbers in this assay, from the lowest: compounds 3 and 4 (each within the scatter of the next); then compounds 1 and 2 (each within the scatter of the next).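

In this assay, methyl can stand in place of methoxy on this ring with no real loss (a 2.0-fold higher number from compound 3 to compound 4 (0.30 log units; within the scatter)). So the oxygen of the methoxy is not required to keep the number low in this pair. Replacing the whole 3-bromo-4-methoxyphenyl with 3,4-dimethylphenyl still gives a clear gain (a 7.5-fold lower number from compound 2 to compound 4 (0.88 log units; beyond the scatter)), and no measurement available here accounts for either step.

As far as these compounds go, what remains open is how an amine or a longer chain such as ethoxy would read at this place on the ring.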